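Swapping hept-1-en-1-yl for tert-butyl on the shared core

The compounds below may be only part of what the source reports. "The series", "measured", "known", "first", "only" and "open" are said of these compounds alone.

compound 1 `CCCCCCCCCc1cc(-c2ccc3cc(C(=O)O)ccc3c2)ccc1O` gives 1.73 ug/mL
compound 2 `CCCCCC=Cc1cc(-c2ccc3cc(CO)ccc3c2)ccc1O` gives 4.19 ug/mL

In a functional assay on HepG2 cells (Homo sapiens) for cytotoxicity, read by WST assay, with a stated time of 24 h (a lower number here means that less compound is tolerated, a higher number that more compound is tolerated), compound 2 (4.19 ug/mL) holds the higher of the two numbers, and its gap to compound 1 (1.73 ug/mL) lies beyond the scatter. Compound 3 `CC(C)(C)c1cc(-c2ccc3cc(CO)ccc3c2)ccc1O` carries tert-butyl in place of hept-1-en-1-yl on an aromatic carbon, ortho to a hydroxy group (tert-butyl in place of hept-1-en-1-yl on an aromatic carbon). Within the data shown here, no measured pair shows this kind of change, so the expectation is loose. A moderate upward step is expected in this assay (a 2.1-fold higher number from compound 2 to compound 3 (0.33 log units; beyond the scatter)), meaning more compound tolerated. Compound 3 is estimated at 9 ug/mL (3.5 ug/mL to 25 ug/mL).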

Compound 3, concentration lethal to 50% of the cells: 7.5 ug/mL
Compound 3: middle estimate off by 1.2-fold (0.08 log units), on the high side; the range from low to high includes it.
By their numbers in this assay, from the lowest: compound 1; then compounds 2 and 3 (each within the scatter of the next).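

In this assay, this position, on an aromatic carbon ortho to a hydroxy group, now has its first one-place comparison: a 1.8-fold higher number from compound 2 to compound 3 (0.25 log units; within the scatter). Exchanging hept-1-en-1-yl for tert-butyl therefore leaves the reading indistinguishable from that of the chain-bearing compound, although the double bond outside aromatic rings and part of the carbon count are gone. Nothing available gives a measured explanation for this result.

From the compounds shown here alone, how an amine or an amide at this position would read remains open. So does the separate contribution of each place in which compound 1 differs from compound 2.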